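Expected Liver-Cell Tolerance After an Aryl Change

The compounds below may be only part of what the source reports. "The series", "measured", "known", "first", "only" and "open" are said of these compounds alone.

Compound 1, `N#CC1=C(N)Oc2c(c3nc4ccccc4nc3c3ccccc23)C12C(=O)N(Cc1cnnn1-c1ccc(Br)cc1)c1ccccc12`, sits at a limit in an ADME assay on L02 cells (Homo sapiens) for antiproliferative activity, read by MTT assay, with a stated time of 48 h; on this read-out lower numbers stand for stronger inhibition and higher numbers for weaker inhibition: > 50000 nM.
Compound 2, `N#CC1=C(N)Oc2c(c3nc4ccccc4nc3c3ccccc23)C12C(=O)N(Cc1cnnn1-c1ccc(Cl)c(Cl)c1)c1ccccc12`, sits at a limit in this assay: > 50000 nM.
Compound 3, `N#CC1=C(N)Oc2c(N)cc3nc4ccccc4nc3c2C12C(=O)N(Cc1cnnn1-c1ccc(F)cc1)c1ccccc12`, sits at a limit in this assay: > 50000 nM.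

Compound 3 therefore stands where every measured compound stands: at the same limit, as the limit of > 50000 nM in this assay, at which 3 of the 3 values shown sit, makes clear, so none of the three shows measurable inhibition of these liver cells. For the measured compounds named here, the single step between measured compounds, a step that the two limits leave unreadable from compound 1 to compound 2, cannot be read in size because both ends are limits. Compound 4, `CCc1cccc(C)c1-n1nncc1CN1C(=O)C2(C(C#N)=C(N)Oc3c(N)cc4nc5ccccc5nc4c32)c2ccccc21`, changes the group on the aromatic nitrogen: 2-ethyl-6-methylphenyl in place of 4-fluorophenyl on an aromatic nitrogen. Going by the values given here, no measured step tracks this particular change, and the one step that does swap the group on that nitrogen gives no sign of leaving the limit. The expectation for compound 4 is therefore a step that the limit leaves unreadable from compound 3 to compound 4 that amounts to nothing beyond the scatter. Compound 4 is estimated at 60000 nM, with a range from 25000 nM to 150000 nM, most likely reported again only as a limit.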

Compound 4, half-maximal inhibitory concentration: > 50000 nM
Compound 4: a limit, no number; the forecaster's own chance of this, stated with the estimate: 80%; the middle value lies beyond the limit too.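

Compound 3 and compound 4 both stand at a limit and not at a number, so no step in size can be read between them: the limit of > 50000 nM in this assay, at which 4 of the 4 values shown sit.

The compounds shown leave open how far beyond that limit each one lies, and whether any group on that nitrogen would give measurable inhibition in this assay.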